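The source may report more compounds than this note shows. Statements on the series, on what has been measured and on what is new or still open speak of the compounds shown alone.

Compound 1 `Cc1ccc(NC(=O)CN2CCN(S(=O)(=O)N3CCC(C)CC3)CC2)cc1` gives 4100 nM in an assay on HEK293 cells for activation of potassium channel subfamily T member 1 (Homo sapiens), read by thallium flux; on this read-out lower numbers stand for an effect already at smaller amounts and higher numbers for an effect only at larger amounts of compound.
Compound 2 `CC1CCN(S(=O)(=O)N2CCN(CC(=O)Nc3cccc(Cl)c3)CC2)CC1` gives 7600 nM in this assay.
Compound 3 `CC1CCN(S(=O)(=O)N2CCN(CC(=O)Nc3ccc(F)cc3)CC2)CC1` gives only an assay limit in this assay, > 10000 nM.

Compound 3 thus stands at the floor of the numbers seen here, (the limit of > 10000 nM in this assay, at which 1 of the 3 values shown sits), and its true number is not known. Compound 4 `CC1CCN(S(=O)(=O)N2CCN(CC(=O)Nc3cc(Cl)ccc3F)CC2)CC1` differs from compound 3 by 5-chloro-2-fluorophenyl in place of 4-fluorophenyl on an amide-type nitrogen. Among the measured compounds shown here, two measured steps bear on this change. Going an at least 1.3-fold higher number from compound 2 to compound 3 (0.11 log units; that floor lies within the scatter), so the presence of chlorine on the ring gave a number that can be read as a value rather than a limit. Going an at least 2.4-fold higher number from compound 1 to compound 3 (0.38 log units; beyond the scatter), the fluoro ring was the weaker of the pair. Going a 1.9-fold higher number from compound 1 to compound 2 (0.27 log units; within the scatter), the chloro and methyl rings sit within the scatter of each other. Compound 4 keeps the fluorine and adds chlorine; the expectation is for a number near the limit, perhaps slightly lower, with a real chance that this assay again reports only a limit. Compound 4 is estimated at 10000 nM, with a range from 4000 nM to 30000 nM. This estimate means an expected step of a number no higher from compound 3 to compound 4 (the limit leaves the size open), not clearly beyond the scatter.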

Compound 4, half-maximal effective concentration: 3800 nM
For compound 4 the middle estimate is 2.6-fold (0.42 log units) above the measured one; the whole stated range lies above it.
By their numbers in this assay, from the lowest: compounds 4, 1 and 2 (each within the scatter of the next). At a limit, above all of these: compound 3.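

On the amide-type nitrogen, 5-chloro-2-fluorophenyl turns a limit into a readable number in this assay, with an at least 2.6-fold lower number from compound 3 to compound 4 (0.42 log units; beyond the scatter), so fluorine on the ring does not by itself keep a compound out of the measurable range. Adding that fluorine to the chlorinated ring gives a 2.0-fold lower number from compound 2 to compound 4 (0.30 log units; within the scatter), and the same ring set against 4-methylphenyl gives a 1.1-fold lower number from compound 1 to compound 4 (0.03 log units; within the scatter), so the three readable aryl groups in this assay do not separate. Compound 3 remains a limit and not a number, which leaves the size of its step open: the limit of > 10000 nM in this assay, at which 1 of the 4 values shown sits.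

Still open, from the compounds shown here alone, is whether any aryl group on this nitrogen moves the number clearly beyond the scatter of these three. Going by these compounds, a nitrile or a methoxy group in place of the chlorine would test whether chlorine itself matters, and the shared core remains unexplored.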